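From Vinyl to 2-Methylprop-1-en-1-yl on the Amide Carbonyl

The compounds below may be only part of what the source reports. "The series", "measured", "known", "first", "only" and "open" are said of these compounds alone.

Among the measured compounds shown here, in a functional assay on MCF7 cells (Homo sapiens) for antiproliferative activity, read by MTT assay, with a stated time of 72 h (on this read-out higher numbers stand for weaker inhibition and lower numbers for stronger inhibition), compound 2 (`C=CC(=O)Nc1cccc(Oc2nc(Nc3ccc(OC)cc3)nc3c2CSCC3)c1`) gives 11700 nM as the only true number so far. Compound 3 (`COc1ccc(Nc2nc3c(c(Oc4cccc(NC(=O)C=C(C)C)c4)n2)CSCC3)cc1`) differs from it by having 2-methylprop-1-en-1-yl in place of vinyl on a carbonyl carbon. Compound 1 (`CC(C)=CC(=O)Nc1cccc(Oc2nc(Nc3ccn(C)n3)nc3c2CSCC3)c1`) carries the same group and reads > 50000 nM as a limit of this assay and not a number, so weaker inhibition is expected for compound 3 than for compound 2. The estimated 2.4-fold higher number from compound 2 to compound 3 (0.38 log units; beyond the scatter) would lie beyond the scatter. Compound 3 is expected at 28000 nM within a range from 12000 nM to 60000 nM in this assay once measured.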

Compound 3, half-maximal inhibitory concentration: > 50000 nM
Compound 3: only a limit was reported (the forecaster's own chance of this, stated with the estimate: 40%); middle value at least 1.7-fold (0.25 log units) from the limit.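

On a carbonyl carbon whose other neighbour is an amide-type nitrogen, 2-methylprop-1-en-1-yl in place of vinyl weakens inhibition in this assay, giving an at least 4.2-fold higher number from compound 2 to compound 3 (0.63 log units; beyond the scatter). That step has only a lower bound, and the real loss may be larger: the limit of > 50000 nM in this assay, at which 2 of the 3 values shown sit. Compound 1 and compound 3 both stand as limits, and the step between them cannot be read.

As far as these compounds go, whether a single methyl on the vinyl, as in a prop-1-en-1-yl group, already weakens inhibition remains open. So does the effect of an amine at the end of that chain.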